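Adding a chloro group to compound 3

The source may hold more compounds than are shown below. What is called first, only, known or untested is meant among the compounds shown, and "the series" means these compounds.

Measured in a functional assay on HeLa cells (Homo sapiens) for antiproliferative activity, read by MTT assay, with a stated time of 48 h; on this read-out lower numbers stand for stronger inhibition and higher numbers for weaker inhibition:
Compound 1 `COc1ccc(N(C)c2ccnc(Cl)n2)cc1OCCBr`: 3310 nM
Compound 2 `COc1ccc(N(C)c2ccnc(Cl)n2)cc1OCCCCBr`: 307 nM
Compound 3 `COc1ccc(N(C)c2cc(C)nc(C)n2)cc1`: 322 nM

Compound 3, at 322 nM, lies within the usual scatter of compound 2, and the two cannot be told apart on these numbers. Compound 1 gives a clearly higher number, 3310 nM. The next compound to be tested is compound 4 `COc1ccc(N(C)c2cc(C)nc(C)n2)cc1Cl`. It keeps the structure of compound 3 but has chloro in place of hydrogen on an aromatic carbon, ortho to a methoxy group: chloro in place of hydrogen on an aromatic carbon.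

Among the measured compounds shown here, only one measured step is available, an 11-fold lower number from compound 1 to compound 2 (1.03 log units; beyond the scatter). It is large, which shows that a single change among these compounds can move the number well beyond the scatter. For the measured compounds named here, that step alters a side chain ending in bromine, however, and no measured pair swaps hydrogen for chloro. It therefore offers no direct guide to the size or direction of this change. With no evidence for either direction, the expected result in this assay is no step beyond the scatter, though the uncertainty is wide. The estimated change is a 1.1-fold lower number from compound 3 to compound 4 (0.03 log units; within the scatter). Compound 4 is expected at 300 nM, with an estimated range of 90 nM to 1000 nM.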

Compound 4, half-maximal inhibitory concentration: 316 nM
Compound 4: the middle estimate sits 1.1-fold (0.02 log units) below what was measured; the measured number falls inside the stated range.
By their numbers in this assay, from the lowest: compounds 2, 4 and 3 (each within the scatter of the next); then compound 1.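

In this assay, the step from hydrogen to chloro on this aromatic carbon, ortho to a methoxy group, is a 1.0-fold lower number from compound 3 to compound 4 (0.01 log units; within the scatter), so this position carries a single chlorine atom with no change that can be told from the scatter. Among the compounds shown here, this is the first measured swap of hydrogen for chloro, and it contrasts with the only earlier step, an 11-fold lower number from compound 1 to compound 2 (1.03 log units; beyond the scatter), which showed that a change to a side chain ending in bromine can move the number far beyond the scatter; the two steps lie at different places on different compounds, so this contrast sets no rule for the series. No measurement of any property of these compounds bears on this result, and the flat step remains without an explanation.

The compounds shown leave open whether this carbon would tolerate other groups, such as an amine, a carboxylic acid or a longer chain, as it tolerates chloro. They also leave open whether the same swap of hydrogen for chloro would stay within the scatter on the core of compound 2.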